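Adding a nitro group to compound 1

This account rests on a few compounds, and the source may have more. Where it says the series, first, only, none or still open, it means among the compounds named here.

- compound 1 `C#CCN(Cc1ccc2nc(C)nc(O)c2c1)c1ccccc1` gives > 10700 nM (a limit)
- compound 2 `C#CCN(Cc1ccc2nc(C)nc(O)c2c1)c1cccc(Br)c1` gives 5700 nM

In a functional assay on CCRF-CEM cells (Homo sapiens) for inhibition (on this read-out lower numbers stand for stronger inhibition and higher numbers for weaker inhibition), compound 1 gives > 10700 nM as a limit of the assay, not as a number. Still unmeasured is compound 3 `C#CCN(Cc1ccc2nc(C)nc(O)c2c1)c1ccc([N+](=O)[O-])cc1`, which differs from it by one change: nitro in place of hydrogen on an aromatic carbon. In short, nitro takes the place of hydrogen on an aromatic carbon, para to a large group.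

Among the measured compounds shown here, only one measured step bears on this, and it involves a different group. Putting bromo in place of hydrogen on an aromatic carbon gives an at least 1.8-fold lower number from compound 1 to compound 2 (0.27 log units; that floor lies within the scatter). Its floor lies within the scatter, so it is only a weak guide. A modest move towards a lower number is therefore expected, and another limit remains possible.

The expected change is an at least 1.5-fold lower number from compound 1 to compound 3 (0.18 log units; that floor lies within the scatter) in this assay as an estimate. For compound 3 the estimate is 7000 nM, with an expected range from 2500 nM to 20000 nM.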

Compound 3, half-maximal inhibitory concentration: > 4800 nM
Compound 3 ended at the assay's limit (the forecaster's own chance of this, stated with the estimate: 35%); the middle value does not contradict the limit.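

Compound 1 and compound 3 both sit at limits in this assay rather than at numbers, so the step between them cannot be read. The compounds shown leave open whether nitro in place of hydrogen on an aromatic carbon changes inhibition at all, and in which direction.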